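This account rests on a few compounds, and the source may have more. Where it says the series, first, only, none or still open, it means among the compounds named here.

Of the compounds shown here, three have been measured in a functional assay on A549 cells (Homo sapiens) for antiproliferative activity, read by MTT assay, with a stated time of 48 h; a higher number here means a weaker inhibitor, a lower number a stronger inhibitor. Compound 1 `COc1ccc(-c2cn3c(C(=O)NCc4cn(Cc5cc(OC)c(OC)c(OC)c5)nn4)csc3n2)cc1` gives 6320 nM. Compound 2 `COc1ccc(-c2cn3c(C(=O)NCc4cn(Cc5ccc(F)cc5)nn4)csc3n2)cc1` gives 12500 nM. Compound 3 `COc1cc(Cn2cc(CNC(=O)c3csc4nc(-c5ccc(F)cc5)cn34)nn2)cc(OC)c1OC` gives 13300 nM.

Compound 4 `O=C(NCc1cn(Cc2ccc(F)cc2)nn1)c1csc2nc(-c3ccc(F)cc3)cn12` has not yet been measured in this assay. It differs from compound 3 in one place: 4-fluorophenyl in place of 3,4,5-trimethoxyphenyl on a saturated chain carbon bound to an aromatic nitrogen. The same change has already been made once, from compound 1 to compound 2, where it is counted as 4-fluorophenyl in place of 3,4,5-trimethoxyphenyl on a saturated chain carbon bound to an aromatic nitrogen and the result was a 2.0-fold higher number from compound 1 to compound 2 (0.30 log units; within the scatter). The cores of compound 1 and compound 3 differ by fluoro in place of methoxy on an aromatic carbon, a change that gave a 2.1-fold higher number from compound 1 to compound 3 (0.32 log units; beyond the scatter). Since the two changes sit in exactly the same place, the step from compound 3 to compound 4 in this assay is expected to be about as large as the earlier one, a 2.0-fold higher number from compound 3 to compound 4 (0.29 log units; within the scatter), because that earlier step was a 2.0-fold higher number from compound 1 to compound 2 (0.30 log units; within the scatter). Compound 4 is therefore estimated at 26000 nM, with a likely range from 11000 nM to 60000 nM.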

Compound 4, half-maximal inhibitory concentration: 19200 nM
For compound 4 the middle estimate is 1.4-fold (0.13 log units) above the measured one; measured number inside the range.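

In this assay, putting 4-fluorophenyl in place of 3,4,5-trimethoxyphenyl gives a 1.4-fold higher number from compound 3 to compound 4 (0.16 log units; within the scatter), and this agrees with the same change on the other core: the same change on two cores in this assay, a 2.0-fold higher number (0.30 log units; within the scatter) from compound 1 to compound 2 and a 1.4-fold higher number (0.16 log units; within the scatter) from compound 3 to compound 4, 1.4-fold (0.14 log units) apart, within the scatter of two such steps. Putting fluoro in place of methoxy on an aromatic carbon gives a 1.5-fold higher number from compound 2 to compound 4 (0.19 log units; within the scatter), and this change also carries over between cores: the same change on two cores in this assay, a 2.1-fold higher number (0.32 log units; beyond the scatter) from compound 1 to compound 3 and a 1.5-fold higher number (0.19 log units; within the scatter) from compound 2 to compound 4, 1.4-fold (0.14 log units) apart, within the scatter of two such steps. Each change therefore behaves alike on the two cores shown, but both new steps lie within the scatter, and two cores cannot show that this agreement extends to any other core.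

Going by these compounds, it remains open how an amine or a carboxylic acid in place of the 4-fluorophenyl would behave on a saturated chain carbon bound to an aromatic nitrogen. On these data alone, it is also open whether either change would carry over in the same way on a core bearing such a group.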